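The source may report more compounds than this note shows. Statements on the series, on what has been measured and on what is new or still open speak of the compounds shown alone.

Compound 1 `CCCCCCCCCCCCCCNC(=O)[C@H](CO)/N=C/c1ccccc1Cl` gives 10300 nM in a functional assay on cells (Homo sapiens) for cytotoxicity, read by MTT assay, with a stated time of 24 h; a lower number here means a stronger inhibitor, a higher number a weaker inhibitor. Going by the values given here, compound 2 `CCCCCCCCCCCCCCNC(=O)[C@H](CO)/N=C/c1ccccc1[N+](=O)[O-]` gives 21700 nM in this assay, and the single step measured so far, a 2.1-fold higher number from compound 1 to compound 2 (0.32 log units; beyond the scatter), is an exchange of one aromatic substituent for another on the same ring. Compound 2 thus holds the highest of the two numbers recorded, with compound 1 nearest at a lower value. Compound 3 `CCCCCCCCCCCCCCNC(=O)[C@H](CO)/N=C/c1cccc(OC)c1` differs from compound 2 by 3-methoxyphenyl in place of 2-nitrophenyl on a carbon with a double bond to nitrogen. Among the compounds with values here, no measured step covers this particular change; the one step available, a 2.1-fold higher number from compound 1 to compound 2 (0.32 log units; beyond the scatter), concerned a different pair of substituents on the same ring and was modest, so it serves only as a rough guide to how much this part of the molecule moves the number. For compound 3 a small step is expected, a 1.6-fold lower number from compound 2 to compound 3 (0.19 log units; within the scatter), with no firm case for either direction. Compound 3 is estimated at 14000 nM in this assay, within 6000 nM to 35000 nM.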

Compound 3, half-maximal inhibitory concentration: 31300 nM
Estimate against measurement, compound 3: 2.2-fold (0.35 log units) below; the range from low to high includes it.
By their numbers in this assay, from the lowest: compound 1; then compounds 2 and 3 (each within the scatter of the next).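

In this assay, 3-methoxyphenyl in place of 2-nitrophenyl on a carbon with a double bond to nitrogen gives a 1.4-fold higher number from compound 2 to compound 3 (0.16 log units; within the scatter) and so does not separate these two groups. The same place does respond to other exchanges: 3-methoxyphenyl in place of 2-chlorophenyl gives a 3.0-fold higher number from compound 1 to compound 3 (0.48 log units; beyond the scatter) and shows that compound 1 stands apart from both compound 2 and compound 3, not only from the nitro analogue. No measured evidence bears on the reason for this result.

The three compounds change both the group and its printed ring location, so the effect of the chloro group cannot be separated from that of its location. Going by these compounds, how an amine or a carboxylic acid on the phenyl ring would read in this assay also remains open, as does the effect of a shorter chain on the amide nitrogen.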